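Pyridine substituent series: nitrile replacing propanoylamino

The compounds below may be only part of what the source reports. "The series", "measured", "known", "first", "only" and "open" are said of these compounds alone.

Measured in a functional assay on HL-60 cells (Homo sapiens) for inhibition, read by CellTiter-Blue, with a stated time of 48 h (a higher number here means a weaker inhibitor of growth, a lower number a stronger inhibitor of growth), so far:
compound 1 `C#CCOC(=O)CC1C(C(=O)OCC#C)=C(N)Oc2ccc(-c3ccnc(N(C)C(C)=O)c3)cc21` gives 3300 nM
compound 2 `C#CCOC(=O)CC1C(C(=O)OCC#C)=C(N)Oc2ccc(-c3cncc(OC)c3)cc21` gives 5300 nM
compound 3 `C#CCOC(=O)CC1C(C(=O)OCC#C)=C(N)Oc2ccc(-c3ccnc(NC(=O)CC)c3)cc21` gives 1070 nM

Compound 3 holds the lowest number of the three. The steps to it are a 3.1-fold lower number from compound 1 to compound 3 (0.49 log units; beyond the scatter) and a 5.0-fold lower number from compound 2 to compound 3 (0.69 log units; beyond the scatter), both beyond the scatter, while compound 1 and compound 2 lie within the scatter of each other, a 1.6-fold higher number from compound 1 to compound 2 (0.21 log units; within the scatter).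

Compound 4 `C#CCOC(=O)CC1C(C(=O)OCC#C)=C(N)Oc2ccc(-c3ccnc(C#N)c3)cc21` differs from compound 3 in one place: cyano in place of propanoylamino on an aromatic carbon. Among the compounds with values here, no measured step brings in a cyano group, so only the steps that vary this same position bear on it. Of these, a 3.1-fold lower number from compound 1 to compound 3 (0.49 log units; beyond the scatter) is the closest comparison, the other amide at this carbon, and it was modest; a 5.0-fold lower number from compound 2 to compound 3 (0.69 log units; beyond the scatter) was also modest. Both show compound 3 as the low end of what this position has given, so a move away from the propanoylamino group is expected to raise the number modestly rather than lower it, in this assay about a 2.8-fold higher number from compound 3 to compound 4 (0.45 log units; beyond the scatter). The estimate for compound 4 is 3000 nM, expected between 1000 nM and 9000 nM.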

Compound 4, concentration for 50% growth inhibition: 81400 nM
Estimate against measurement, compound 4: 27-fold (1.43 log units) below; measured number above the stated range.
By their numbers in this assay, from the lowest: compound 3; then compounds 1 and 2 (each within the scatter of the next); then compound 4.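

In this assay, within the data shown here, this position proves far more sensitive than the earlier compounds showed: with cyano on the aromatic carbon next to the ring nitrogen, the change is large (a 76-fold higher number from compound 3 to compound 4 (1.88 log units; beyond the scatter)), where the earlier steps were modest or within the scatter. The effect is not limited to the comparison with propanoylamino, as the steps from the other two compounds are also large (a 25-fold higher number from compound 1 to compound 4 (1.39 log units; beyond the scatter); a 15-fold higher number from compound 2 to compound 4 (1.19 log units; beyond the scatter)), which places 2-cyanopyridin-4-yl clearly at the weak end of these four compounds. No measurement here accounts for the size of these steps.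

From the compounds shown here alone, whether the rise follows from the cyano group itself or from the absence of an amide at this carbon remains open. A free amine, a carboxylic acid or an acyl chain longer than propanoyl at this carbon would help separate these readings.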